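Swapping the sulfonamide of compound 3 for an oxazole

This account rests on a few compounds, and the source may have more. Where it says the series, first, only, none or still open, it means among the compounds named here.

Among the measured compounds shown here, compound 3 `CS(=O)(=O)Nc1cccc2c1CCC2c1ncc[nH]1` stands highest of the three compounds measured so far: in a functional assay on CHO cells for agonist activity at Alpha-1A adrenergic receptor (Homo sapiens), read by FLIPR and calcium flux (a higher number here means a larger maximal response, a lower number a smaller maximal response), compound 3 reaches 87%. Compound 1 `c1ccc(-c2cccc3c2CCC3c2ncc[nH]2)nc1`, which carries pyridin-2-yl on an aromatic carbon, gives 53% in this assay, and compound 2 `CCCS(=O)(=O)Nc1cccc2c1CCC2c1ncc[nH]1`, which carries (propylsulfonyl)amino on that aromatic carbon, gives 54%. Both steps up to compound 3 are large: a number 34 percentage points higher from compound 1 to compound 3 (beyond the scatter) and a number 33 percentage points higher from compound 2 to compound 3 (beyond the scatter). Between the other two compounds the step is small, a number 1 percentage points higher from compound 1 to compound 2 (within the scatter).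

Compound 4 `Cc1oncc1-c1cccc2c1CCC2c1ncc[nH]1` has not yet been measured. It differs from compound 3 in one place: 5-methyl-1,2-oxazol-4-yl in place of methanesulfonamido on an aromatic carbon. For the measured compounds named here, the step that bears most on this change is the one from compound 1 to compound 3, because compound 1 gives 53% with an aromatic ring in the place where compound 3 carries methanesulfonamido, and compound 4 again carries an aromatic ring there. The step from compound 2 to compound 3 points the same way, as removing the methanesulfonamido in favour of anything else seen so far has gone with a smaller response. Compound 4 is therefore expected to fall by about a number 29 percentage points lower from compound 3 to compound 4 (beyond the scatter) in this assay, a downward step beyond the scatter. The estimate for compound 4 in this assay is 58%, with a range from 40% to 80%.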

Compound 4, largest response reached (Emax), in percent of the reference or control that the assay uses: 63%
Beside the measured number, compound 4's estimate is 5 percentage points below it; the range from low to high includes it.
By their numbers in this assay, from the lowest: compounds 1, 2 and 4 (each within the scatter of the next); then compound 3.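

In this assay, the step of a number 24 percentage points lower from compound 3 to compound 4 (beyond the scatter) shows that a five-membered aromatic ring with 2 hetero atoms on this aromatic carbon does not keep the response seen with methanesulfonamido, so the earlier result with pyridin-2-yl is not confined to a six-membered ring. The other two steps, a number 9 percentage points higher from compound 2 to compound 4 (within the scatter) and a number 10 percentage points higher from compound 1 to compound 4 (within the scatter), place 5-methyl-1,2-oxazol-4-yl in one group with pyridin-2-yl and (propylsulfonyl)amino, and among these four compounds only compound 3 stands apart from the rest. The data shown offer no explanation for why methanesulfonamido alone stands apart at this position.

Going by these compounds, what remains open is whether the methyl group on the oxazole contributes anything, as the same ring without that methyl group has no value here to compare with compound 4. On these data alone, it is also open how an acetamido group, a plain amine or an ethylsulfonylamino chain would behave on this aromatic carbon, and thus whether the response of compound 3 depends on the sulfonyl group or on the short chain it carries.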